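An Added Methoxy Group on Compound 2

A few compounds are considered here, and "the series" means these few. Any claim that something is new, unique, unknown or untested is made for them only; others in the source may bear on it.

In a functional assay on A549 cells (Homo sapiens) for inhibition, read by sulforhodamine B assay (on this read-out lower numbers stand for stronger inhibition of growth and higher numbers for weaker inhibition of growth), two related compounds have been measured so far. Compound 1 `COc1ccc(-c2ccc(-c3ccc(-c4nc5ccccc5[nH]4)cc3)cc2)cc1OC` gives 7600 nM, and compound 2 `COc1ccc(-c2ccc(-c3ccc(-c4nc5c(O)cccc5[nH]4)cc3)cc2)cc1` gives 7690 nM. These two numbers lie within the scatter of each other, so compound 2 stands level with compound 1 on the available data.

Compound 3 `COc1ccc(-c2ccc(-c3ccc(-c4nc5c(O)cccc5[nH]4)cc3)cc2)cc1OC` has not yet been measured. It differs from compound 2 in one place: methoxy in place of hydrogen on an aromatic carbon. Methoxy takes the place of hydrogen on an aromatic carbon, ortho to a methoxy group and meta to a large group, so that 4-methoxyphenyl becomes 3,4-dimethoxyphenyl. Within the data shown here, no measured pair shows this change on its own, so its size in this assay is not known directly. Compound 1, which already carries 3,4-dimethoxyphenyl, gives 7600 nM, so no step beyond the scatter is expected. The estimated step is a 1.3-fold lower number from compound 2 to compound 3 (0.11 log units; within the scatter). For compound 3 the estimated value is 6000 nM, with an expected range from 2000 nM to 15000 nM.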

Compound 3, concentration for 50% growth inhibition: 1310 nM
Beside the measured number, compound 3's estimate is 4.6-fold (0.66 log units) above it; the whole stated range lies above it.
By their numbers in this assay, from the lowest: compound 3; then compounds 1 and 2 (each within the scatter of the next).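

In this assay, the added methoxy group is not a silent change at this position on a core that carries the hydroxy group: going from 4-methoxyphenyl to 3,4-dimethoxyphenyl gives a 5.9-fold lower number from compound 2 to compound 3 (0.77 log units; beyond the scatter). The hydroxy group also counts once 3,4-dimethoxyphenyl is present, with a 5.8-fold lower number from compound 1 to compound 3 (0.76 log units; beyond the scatter), so compound 3, the only one of the three that holds both groups, stands apart from the other two. Nothing shown here gives a measured reason for either step.

What stays open is whether the methoxy step depends on the hydroxy group, since the compounds shown include no partner with 4-methoxyphenyl on the core of compound 1, and so the two steps cannot be told apart as independent or linked. As far as these compounds go, it is also open whether the gain belongs to methoxy itself at this place, or whether an ethoxy group, a fluorine atom or an amine there would give a step of similar size.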